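Swapping a cyclohexyl thioether on a nucleoside core

The source may report more compounds than this note shows. Statements on the series, on what has been measured and on what is new or still open speak of the compounds shown alone.

Compound 1 `OC[C@H]1O[C@@H](n2cnc3c(SC4CCCCC4)ncnc32)[C@H](O)[C@@H]1O` is the reference point of this small set. In an assay on isolated protein for binding affinity to Equilibrative nucleoside transporter 1 (Homo sapiens) (a higher number here means a weaker inhibitor, a lower number a stronger inhibitor), compound 1 gives 6310 nM, the lowest of the three numbers measured. Compound 2 `CC(C)(Sc1ncnc2c1ncn2[C@@H]1O[C@H](CO)[C@@H](O)[C@H]1O)c1ccccc1` gives 21400 nM in this assay, and the step of a 3.4-fold higher number from compound 1 to compound 2 (0.53 log units; beyond the scatter) lies beyond the scatter. Compound 3 `CC(C)Sc1nc(N)nc2c1ncn2[C@@H]1O[C@H](CO)[C@@H](O)[C@H]1O`, which carries a different thioether and an added amino group on the shared core, gives 191000 nM; it differs from compound 1 in more than one place, so only the two values can be set side by side.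

Compound 4 `OC[C@H]1O[C@@H](n2cnc3c(CSc4ccccc4Br)ncnc32)[C@H](O)[C@@H]1O` has not yet been measured. It differs from compound 1 in one place: ((2-bromophenyl)sulfanyl)methyl in place of cyclohexylsulfanyl on an aromatic carbon. Going by the values given here, the single measured step that bears on this change, a 3.4-fold higher number from compound 1 to compound 2 (0.53 log units; beyond the scatter), likewise exchanged the cyclohexyl for a group bearing a phenyl ring and raised the number modestly. On that basis compound 4 is expected to show a modest weakening, a 2.4-fold higher number from compound 1 to compound 4 (0.38 log units; beyond the scatter), with an estimated 15000 nM in a range from 4000 nM to 60000 nM.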

Compound 4, half-maximal inhibitory concentration: 2400 nM
Beside the measured number, compound 4's estimate is 6.3-fold (0.80 log units) above it, outside the stated range (below it).
By their numbers in this assay, from the lowest: compound 4; then compound 1; then compound 2; then compound 3.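

In this assay, the step of a 2.6-fold lower number from compound 1 to compound 4 (0.42 log units; beyond the scatter) shows that this aromatic carbon of the shared core accepts the larger ((2-bromophenyl)sulfanyl)methyl group in place of cyclohexylsulfanyl without a loss, and with a modest gain. Set against the step of a 3.4-fold higher number from compound 1 to compound 2 (0.53 log units; beyond the scatter) in the opposite direction, it also shows that a substituent carrying a six-membered aromatic ring does not by itself raise the number in this set. Nothing available here accounts for the difference between these two steps.

The single change to compound 4 brings in the bromine, the aromatic ring and the methyl linking carbon together, and the compounds shown do not separate their contributions. From the compounds shown here alone, whether a plain phenylsulfanylmethyl group, or a chlorine or an amine in place of the bromine, would keep the lower number remains open.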